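Halogen swap at the brominated aryl position in compound 3

The source may hold more compounds than are shown below. What is called first, only, known or untested is meant among the compounds shown, and "the series" means these compounds.

Three compounds of this series have been run in a functional assay on MDA-MB-468 cells (Homo sapiens) for cytotoxicity, read by sulforhodamine B assay, with a stated time of 48 h; a lower number here means a stronger inhibitor of growth, a higher number a weaker inhibitor of growth. Compound 1 `Cc1ccc2nc(/N=C3\C(=O)N(CN(C)C)c4cccc(Br)c43)sc2c1` gives 27400 nM. Compound 2 `Cc1ccc2nc(/N=C3\C(=O)N(CN(C)C)c4ccccc43)sc2c1` gives 35500 nM; the change from compound 1 to compound 2 is a 1.3-fold higher number from compound 1 to compound 2 (0.11 log units; within the scatter). Compound 3 `Cc1ccc2nc(/N=C3\C(=O)N(CN4CCCCC4)c4cccc(Br)c43)sc2c1` gives 24000 nM, the lowest of the three numbers, although its gaps to compound 1 and to compound 2 are both within the scatter, so the three sit together rather than in any order worth reading. The step from compound 1 to compound 3 was a 1.1-fold lower number from compound 1 to compound 3 (0.06 log units; within the scatter).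

Compound 4 `Cc1ccc2nc(/N=C3\C(=O)N(CN4CCCCC4)c4cccc(Cl)c43)sc2c1` is not yet measured. Relative to compound 3 the difference is chloro in place of bromo on an aromatic carbon. Among the compounds with values here, the only measured step touching this position, from compound 1 to compound 2, removed the bromo altogether and still stayed within the scatter, which suggests that exchanging one halogen for another at the same carbon will not move the number beyond the scatter either. The step from compound 3 to compound 4 is therefore expected to be no change at the digits printed from compound 3 to compound 4 (within the scatter). For compound 4 the estimated value in this assay is 24000 nM, with a range from 11000 nM to 55000 nM.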

Compound 4, concentration for 50% growth inhibition: 19800 nM
Compound 4: the middle estimate sits 1.2-fold (0.08 log units) above what was measured; low and high end bracket the measured number.
By their numbers in this assay, from the lowest: compounds 4, 3, 1 and 2 (each within the scatter of the next).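

In this assay the step from bromo to chloro at this aromatic carbon can now be read directly, on the piperidin-1-yl side chain, and it gives a 1.2-fold lower number from compound 3 to compound 4 (0.08 log units; within the scatter). The earlier step at this carbon replaced bromo with hydrogen on the dimethylamino side chain, so a change here has now stayed within the scatter on both side chains, a statement limited to these two pairs. No available evidence bears on the cause of either result.

Open, from the compounds shown here alone, is whether a non-halogen group at this aromatic carbon, such as methoxy or a carboxylic acid, would move the number beyond the scatter. Also open, going by these compounds, is whether removing the halogen altogether on the piperidin-1-yl side chain would leave the number within the scatter of compound 3.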